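Replacing Vinyl with Amino in the HEp-2 Cytotoxicity Series

The source may hold more compounds than are shown below. What is called first, only, known or untested is meant among the compounds shown, and "the series" means these compounds.

Measured in an ADME assay on HEp-2 cells (Homo sapiens) for cytotoxicity; on this read-out lower numbers stand for higher toxicity in this test and higher numbers for lower toxicity in this test:
Compound 1 `CNCc1ccc2c(c1)nc(Cn1c(=O)n(C(C)C)c3ccccc31)n2CCC(C)C`: 1480 nM
Compound 2 `C=Cc1ccc2c(c1)nc(Cn1c(=O)n(C(C)C)c3ccccc31)n2CCC(C)C`: 6520 nM

Compound 2 stands highest of the two measured compounds, at 6520 nM. Compound 3 `CC(C)CCn1c(Cn2c(=O)n(C(C)C)c3ccccc32)nc2cc(N)ccc21` has amino in place of vinyl on an aromatic carbon. Going by the values given here, the one measured step that bears on this change is modest: a 4.4-fold higher number from compound 1 to compound 2 (0.64 log units; beyond the scatter). Among the compounds with values here, it involves vinyl at the same place, but no measured compound carries amino. Leaving vinyl is therefore expected to give a lower number in this assay, with a somewhat smaller step: a 2.2-fold lower number from compound 2 to compound 3 (0.34 log units; beyond the scatter). The estimate for compound 3 is 3000 nM, with an expected range of 900 nM to 9000 nM.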

Compound 3, half-maximal cytotoxic concentration: 32200 nM
For compound 3 the middle estimate is 11-fold (1.03 log units) below the measured one; the whole stated range lies below it.
By their numbers in this assay, from the lowest: compound 1; then compound 2; then compound 3.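

In this assay amino on this aromatic carbon gives a 4.9-fold higher number from compound 2 to compound 3 (0.69 log units; beyond the scatter) and a 22-fold higher number from compound 1 to compound 3 (1.34 log units; beyond the scatter) as the series' largest step. Leaving vinyl for amino therefore raises the number here, and of the three groups at this place amino stands highest and (methylamino)methyl lowest. Nothing measured here accounts for this order. The compounds shown leave open whether a hydroxyl group or a dimethylamino group at this place would stand as high as amino, and whether the same order would hold on a different core.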